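Swapping the aryl group again on a shared scaffold with low numbers

The source may report more compounds than this note shows. Statements on the series, on what has been measured and on what is new or still open speak of the compounds shown alone.

Of the compounds shown here, two of a shared core have been measured in an assay on isolated protein for inhibition of serine protease 1 (Homo sapiens), tested at 100 uM; a lower number here means less inhibition, a higher number more inhibition at the concentration tested (going by the name of the read-out). Compound 1 `CC1CCCC(C)N1CCCCCN1C(=O)C(c2ccccc2)Oc2ccccc21` gives 2.8%, and compound 2 `COc1ccc(C2Oc3ccccc3N(CCCCCN3C(C)CCCC3C)C2=O)cc1OC` gives 0%. Compound 2 stands lowest of the two numbers, though the step of a number 2.8 percentage points lower from compound 1 to compound 2 (within the scatter) is within the scatter, so the two cannot be told apart. Compound 3 `CC1CCCC(C)N1CCCCCN1C(=O)C(c2cccc(C(=N)NO)c2)Oc2ccccc21` carries the change (a group of 10 heavy atoms (7 carbon, 2 nitrogen, 1 oxygen; one six-membered aromatic ring of carbon only) in place of a group of 10 heavy atoms (8 carbon, 2 oxygen; one six-membered aromatic ring of carbon only), on a saturated ring carbon), with the entering group sitting next to the ring oxygen. For the measured compounds named here, the one measured step that bears on this change is the earlier swap at the same saturated ring carbon, a number 2.8 percentage points lower from compound 1 to compound 2 (within the scatter), which did nothing beyond the scatter. Given that both measured compounds sit near zero, the step of a number 5 percentage points higher from compound 2 to compound 3 (within the scatter) is expected to stay within the scatter. Compound 3 is therefore estimated at 5% in this assay, with a range from 0% to 25%.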

Compound 3, a percentage reported as inhibition, at one concentration (the size of the read-out at that concentration, not a potency): 21%
For compound 3 the middle estimate is 16 percentage points below the measured one; the range from low to high includes it.
By their numbers in this assay, from the lowest: compounds 2 and 1 (each within the scatter of the next); then compound 3.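

At this position the group on the saturated ring carbon can shift the number after all in this assay, where the change brings a number 21 percentage points higher from compound 2 to compound 3 (beyond the scatter) and the earlier aryl swap had moved nothing beyond the scatter. Measured against the plain phenyl, adding the hydroxyamidine group to the aromatic ring brings a number 18.2 percentage points higher from compound 1 to compound 3 (beyond the scatter), so the rise goes with this added group and not only with leaving the 3,4-dimethoxyphenyl. These are readings at one concentration, so they show a modest rise in inhibition and not a potency, and nothing here explains the rise.

Going by these compounds, it remains open whether the hydroxyamidine itself is needed, or whether a plain amidine, a carboxylic acid or a primary amine on the same ring would do the same. Whether moving the group to another ring carbon keeps the rise is also unknown.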